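A Larger Group on the Amide-Type Nitrogen

A few compounds are considered here, and "the series" means these few. Any claim that something is new, unique, unknown or untested is made for them only; others in the source may bear on it.

In an ADME assay on microsomes from liver (Rattus norvegicus) for metabolic stability, read by LC-MS, using NADPH, with a stated time of 10 min, tested at 0.1 uM (a higher number here means faster removal of the compound, a lower number slower removal), compound 1 `COc1ccc(F)cc1N1C(=O)CSC1c1cccc(C(=O)NCCCCc2ccccc2)c1` gives 2300 mL.min-1.g-1 and compound 2 `O=C(NCCCCc1ccccc1)c1cccc(C2SCC(=O)N2c2ccccc2F)c1` gives 2950 mL.min-1.g-1, so compound 2 stands within the scatter of compound 1. Compound 3 `CC(F)(F)c1cccc(N2C(=O)CSC2c2cccc(C(=O)NCCCCc3ccccc3)c2)c1` differs from compound 2 on an amide-type nitrogen in a ring: a group of 10 heavy atoms (8 carbon, 2 fluorine; one six-membered aromatic ring of carbon only) in place of a group of 7 heavy atoms (6 carbon, 1 fluorine; one six-membered aromatic ring of carbon only), on an amide-type nitrogen in a ring. Within the data shown here, the only measured step at this place is a 1.3-fold higher number from compound 1 to compound 2 (0.11 log units; within the scatter), and it involves a different group, so it offers limited guidance. The expected step is a 1.1-fold lower number from compound 2 to compound 3 (0.02 log units; within the scatter), with no change expected beyond the scatter. For compound 3, the estimated value is 2800 mL.min-1.g-1, with an expected range of 1400 mL.min-1.g-1 to 5500 mL.min-1.g-1.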

Compound 3, intrinsic clearance in microsomes: 2320 mL.min-1.g-1
Beside the measured number, compound 3's estimate is 1.2-fold (0.08 log units) above it; the range from low to high includes it.
By their numbers in this assay, from the lowest: compounds 1, 3 and 2 (each within the scatter of the next).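

In this assay there is a 1.3-fold lower number from compound 2 to compound 3 (0.10 log units; within the scatter) and a 1.0-fold higher number from compound 1 to compound 3 (0.00 log units; within the scatter) with the group of 10 heavy atoms on the amide-type nitrogen. Groups of 7, 9 and 10 heavy atoms at this place therefore all give numbers within the scatter of one another, so this added size shows no separable effect on removal. Nothing measured here offers an explanation for this result.

Every group shown at this place is a fluorine-bearing six-membered aromatic ring of carbon only. From the compounds shown here alone, what an amine or a carboxylic acid on that ring, or an open alkyl chain in its place, would give remains open.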